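Aryl sulfone series: moving the chlorine on compound 4

The source may hold more compounds than are shown below. What is called first, only, known or untested is meant among the compounds shown, and "the series" means these compounds.

In an assay for binding affinity to Neuropeptide Y receptor type 1 (Homo sapiens), read by radioligand binding (a lower number here means a stronger inhibitor, a higher number a weaker inhibitor), compound 1 `CS(=O)(=O)c1cc(N)c2ncccc2c1[N+](=O)[O-]` gives only a limit, > 10000 nM, which is a limit of the assay (the limit of > 10000 nM in this assay, at which 1 of the 3 values shown sits). Compound 2 `COc1ccc(S(=O)(=O)c2cc(N)c3ncccc3c2[N+](=O)[O-])cc1` gives 1140 nM in this assay. Compound 3 `Nc1cc(S(=O)(=O)c2ccc(Cl)cc2)c([N+](=O)[O-])c2cccnc12` gives 1750 nM in this assay and sits with compound 2 within the scatter, as a 1.5-fold higher number from compound 2 to compound 3 (0.19 log units; within the scatter) shows; of the two numbers reported, it is the one carrying a chlorine on the aryl ring. The steps of an at least 8.7-fold lower number from compound 1 to compound 2 (0.94 log units; beyond the scatter) and an at least 5.7-fold lower number from compound 1 to compound 3 (0.75 log units; beyond the scatter) show that an aryl group in place of methyl on the sulfonyl sulfur is what moves the number, while a 1.5-fold higher number from compound 2 to compound 3 (0.19 log units; within the scatter) shows that exchanging the substituent on that ring does not. Compound 4 `Nc1cc(S(=O)(=O)c2ccccc2Cl)c([N+](=O)[O-])c2cccnc12` differs from compound 3 by 2-chlorophenyl in place of 4-chlorophenyl on a sulfonyl sulfur. Among the compounds with values here, no measured step moves a substituent around the aryl ring, so only the small substituent step bears on this change, and no step beyond the scatter is expected; the expected step is a 1.3-fold higher number from compound 3 to compound 4 (0.10 log units; within the scatter) in this assay. Compound 4 is estimated at 2200 nM in this assay, with a range from 700 nM to 7000 nM.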

Compound 4, inhibition constant: 93 nM
Beside the measured number, compound 4's estimate is 24-fold (1.37 log units) above it; measured number below the stated range.
By their numbers in this assay, from the lowest: compound 4; then compounds 2 and 3 (each within the scatter of the next). At a limit, above all of these: compound 1.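

In this assay, moving the chlorine on the aryl ring changes the number although the atoms stay the same: a 19-fold lower number from compound 3 to compound 4 (1.27 log units; beyond the scatter), whereas exchanging chloro for methoxy did not move it beyond the scatter, a 1.5-fold higher number from compound 2 to compound 3 (0.19 log units; within the scatter). The 2-chlorophenyl group also separates from the 4-methoxyphenyl group, a 12-fold lower number from compound 2 to compound 4 (1.09 log units; beyond the scatter), so among the compounds shown, where the substituent sits on the ring matters as well as whether the sulfonyl sulfur carries an aryl group. Compound 1 stands at a limit, which leaves an at least 100-fold lower number from compound 1 to compound 4 (2.03 log units; beyond the scatter) as a bound only: the limit of > 10000 nM in this assay, at which 1 of the 4 values shown sits.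

Still open, on these data alone, is whether this step belongs to chlorine itself or would hold with methoxy, an amine or a carboxylic acid in its place on the ring of 2-chlorophenyl. As far as these compounds go, how an unsubstituted phenyl group on the sulfonyl sulfur would compare also remains open.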